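This account rests on a few compounds, and the source may have more. Where it says the series, first, only, none or still open, it means among the compounds named here.

Measured compounds:
compound 1 `O=c1cc(Cn2ccnc2)c2ccc(OCc3cccc(Cl)c3)cc2o1`, 101 nM in an assay on V79MZh11B2 cells for inhibition of cytochrome P450 11B2, mitochondrial (Homo sapiens), read by HPLC, with a stated time of 25 min; on this read-out lower numbers stand for stronger inhibition and higher numbers for weaker inhibition
compound 2 `COc1ccc(COc2ccc3c(Cn4ccnc4)cc(=O)oc3c2)cc1`, 124 nM in this assay
compound 3 `CCCOc1ccc(COc2ccc3c(Cn4ccnc4)cc(=O)oc3c2)cc1`, 77 nM in this assay

All three share one core and differ only in the group on the saturated chain carbon bound to an oxygen on an aromatic ring. Compound 2 shows the largest number of the three as written, yet its gaps to the others are both within the scatter: a 1.2-fold higher number from compound 1 to compound 2 (0.09 log units; within the scatter) and a 1.6-fold lower number from compound 2 to compound 3 (0.21 log units; within the scatter).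

Compound 4 `Cc1cccc(COc2ccc3c(Cn4ccnc4)cc(=O)oc3c2)c1` is not yet measured. It differs from compound 2 by 3-methylphenyl in place of 4-methoxyphenyl on a saturated chain carbon bound to an oxygen on an aromatic ring. Among the compounds with values here, the step that bears most on it is the one from compound 1 to compound 2, which also swapped one substituted phenyl for another at this place and stayed within the scatter; the step from compound 2 to compound 3 likewise stayed within the scatter. Nothing here points to a change beyond the scatter, so compound 4 is expected to give a number close to compound 2, the expected step being a 1.2-fold lower number from compound 2 to compound 4 (0.07 log units; within the scatter). The estimate for compound 4 in this assay is 105 nM, with a range from 50 nM to 220 nM.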

Compound 4, half-maximal inhibitory concentration: 250 nM
Estimate against measurement, compound 4: 2.4-fold (0.38 log units) below; measured number above the stated range.
By their numbers in this assay, from the lowest: compounds 3, 1, 2 and 4 (each within the scatter of the next, the first and the last beyond it).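

In this assay, within the data shown here, the step of a 2.5-fold higher number from compound 1 to compound 4 (0.39 log units; beyond the scatter) is the first here to pass beyond the scatter, though only modestly, and it comes from nothing more than methyl in place of chloro on an aromatic carbon, so even a small swap at this place can register. The other new step, a 2.0-fold higher number from compound 2 to compound 4 (0.30 log units; within the scatter), stays within the scatter, so compound 2 and compound 4 cannot be told apart, and the change from 4-methoxybenzyl to 3-methylbenzyl shows no clear effect on its own. No measured evidence here accounts for the step between the chloro and methyl compounds.

The compounds shown leave open how an amine or a carboxylic acid carried on this phenyl group would read in this assay. They also leave open whether methyl in place of chloro gives a step of this size on any other core.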